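Working notes: chain substitution on the purine-type series

A few compounds are considered here, and "the series" means these few. Any claim that something is new, unique, unknown or untested is made for them only; others in the source may bear on it.

Going by the values given here, compound 1 `CC(CCO)n1cnc2c(Cl)nc(F)nc21` is the only member with a measured number: in a functional assay on SW480 cells (Homo sapiens) for antiproliferative activity, read by MTT assay, with a stated time of 48 h (on this read-out lower numbers stand for stronger inhibition and higher numbers for weaker inhibition), compound 1 gives 16800 nM. Compound 2 `CC(CCO)n1cnc2c(Cl)ncnc21` differs by hydrogen in place of fluoro on an aromatic carbon; in this assay compound 2 reaches only > 50000 nM, a limit of the assay rather than a number. The step of an at least 2.9-fold higher number from compound 1 to compound 2 (0.47 log units; beyond the scatter) is therefore known only as a lower bound. Compound 3 `CCCCCCC(CCO)n1cnc2c(N(C)C)ncnc21` also sits at a limit, giving > 50000 nM in this assay. Both limits are the limit of > 50000 nM in this assay, at which 2 of the 3 values shown sit.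

Compound 4 `CC(C)(C)[Si](C)(C)OCC(CCO)n1cnc2c(Cl)nc(F)nc21` is not yet measured. It differs from compound 1 by a group of 8 heavy atoms (6 carbon, 1 oxygen, 1 silicon; no ring) in place of a hydrogen atom, on a saturated chain carbon, two bonds along the chain from an aromatic nitrogen. Among the compounds with values here, no measured step touches this chain carbon; the only measured step concerns the aromatic fluoro, so nothing here speaks directly to the size or direction of the change. The entering group carries no hydrogen-bond donor and one acceptor. Given that two of three values sit at the limit, the expectation is weak and broad. In this assay compound 4 is expected to give about 22000 nM, estimated between 7000 nM and 50000 nM. The expected step is a 1.3-fold higher number from compound 1 to compound 4 (0.12 log units; within the scatter), which is within the scatter.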

Compound 4, half-maximal inhibitory concentration: 8020 nM
Estimate against measurement, compound 4: 2.7-fold (0.44 log units) above; the range from low to high includes it.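

In this assay, the new group on the saturated chain carbon gives a 2.1-fold lower number from compound 1 to compound 4 (0.32 log units; beyond the scatter). Going by these compounds alone, this is the first measured step at this chain carbon, as the earlier step concerned only the aromatic fluoro. It shows that the position accepts a group of this count of heavy atoms with no loss of inhibition, and that the change runs towards stronger inhibition.

Going by these compounds, whether a free hydroxymethyl or a small methoxymethyl at this carbon would move the number the same way stays open, as does whether the silicon atom plays any part in the step. Comparison across the wider series also remains thin: the limit of > 50000 nM in this assay, at which 2 of the 4 values shown sit.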